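A few compounds are considered here, and "the series" means these few. Any claim that something is new, unique, unknown or untested is made for them only; others in the source may bear on it.

Of the compounds shown here, three have been tested in a functional assay on A2780 cells (Homo sapiens) for antiproliferative activity, read by MTT assay, with a stated time of 48 h; a higher number here means a weaker inhibitor, a lower number a stronger inhibitor. Compound 1 `COc1ccc2c(/C=C/C(=O)c3cc(OC)c(OC)c(SC)c3)c[nH]c2c1` gives 139 nM in this assay. Compound 2 `COc1cc(C(=O)/C=C/c2c[nH]c3ccccc23)cc(SC)c1OC` differs from compound 1 in one place: hydrogen in place of methoxy on an aromatic carbon. In this assay compound 2 gives 169 nM, so that a 1.2-fold higher number from compound 1 to compound 2 (0.08 log units; within the scatter). Compound 3 `COc1ccc2c(/C=C(\C)C(=O)c3cc(OC)c(OC)c([Se]C)c3)c[nH]c2c1` is built on a different core; the difference between the cores of compound 1 and compound 3 is not broken down here. In this assay compound 3 gives 18 nM, the lowest of the three numbers, and its gap to compound 1 and to compound 2 is beyond the usual scatter.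

Compound 4 `COc1cc(C(=O)/C(C)=C/c2c[nH]c3ccccc23)cc([Se]C)c1OC` has not yet been measured. It differs from compound 3 in one place: hydrogen in place of methoxy on an aromatic carbon. This is the same change that separates compound 1 from compound 2, made at the same place on the same kind of ring; it occurs twice among these four compounds. On that one earlier step, which stayed within the scatter, the expectation is that removing the methoxy from compound 3 will change little, so the estimated step is a 1.2-fold higher number from compound 3 to compound 4 (0.09 log units; within the scatter). Compound 4 is therefore expected to give about 22 nM in this assay, with the estimate most likely to fall between 10 nM and 48 nM, because the measured step of a 1.2-fold higher number from compound 1 to compound 2 (0.08 log units; within the scatter) was small.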

Compound 4, half-maximal inhibitory concentration: 25 nM
Compound 4: the middle estimate sits 1.1-fold (0.06 log units) below what was measured; low and high end bracket the measured number.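

In this assay, putting hydrogen in place of the methoxy on the core of compound 3 gives a 1.4-fold higher number from compound 3 to compound 4 (0.14 log units; within the scatter), so the methoxy can be removed here without a change that stands out from the usual scatter of repeated measurements. Set beside the same change on the core of compound 1, the two steps agree: the same change on two cores in this assay, a 1.2-fold higher number (0.08 log units; within the scatter) from compound 1 to compound 2 and a 1.4-fold higher number (0.14 log units; within the scatter) from compound 3 to compound 4, 1.1-fold (0.06 log units) apart, within the scatter of two such steps. Among the compounds shown here, this shows that the change carried over between these two cores in this assay, but with only two pairs, both with small steps, it does not show that it would carry over to any other core, and it does not explain why the change behaves alike on both.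

The compounds shown hold only a methoxy or a hydrogen at this place on the ring, so it remains open whether a fluorine atom, an ethoxy group, an amine or a carboxylic acid there would leave the numbers just as little changed. For the compounds shown here, it also remains open which part of the difference between the two cores goes with the lower number of compound 3 compared with compound 1, since no compound here differs from either by just one part of that difference.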